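A few compounds are considered here, and "the series" means these few. Any claim that something is new, unique, unknown or untested is made for them only; others in the source may bear on it.

Working notes on the series. Compound 1 `Cc1cc(C)cc(N2CCN(C(=O)c3oc(C)nc3-c3ccccc3)CC2)c1` and compound 2 `COc1cc(OC)cc(N2CCN(C(=O)c3oc(C)nc3-c3ccccc3F)CC2)c1` share a core and have both been run in an ADME assay on microsomes from liver (Mus musculus) for metabolic stability, read by LC-MS, with a stated time of 1 h, tested at 5 uM; on this read-out lower numbers stand for a less stable compound and higher numbers for a more stable compound. Compound 1 gives 12% and compound 2 gives 16.6% in this assay; the two numbers lie within the scatter of each other, so compound 1 stands alongside compound 2 at a low remaining fraction, with no separation between them. For the measured compounds named here, no step between measured compounds can be drawn from these two. Compound 3 `Cc1ccc(C)c(N2CCN(C(=O)c3oc(C)nc3-c3ccccc3)CC2)c1` is the next compound and differs from compound 1 in one place: 2,5-dimethylphenyl in place of 3,5-dimethylphenyl on an amine nitrogen in a ring. Going by the values given here, with only two measured compounds, both at a low fraction remaining, and no step to rest on, the expectation for compound 3 is a change no larger than the scatter, in no particular direction, an estimated step of a number 3 percentage points higher from compound 1 to compound 3 (within the scatter). Compound 3 is therefore estimated to remain at about 15% in this assay, with a range from 5% to 30%.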

Compound 3, percent of the compound remaining: 1.4%
For compound 3 the middle estimate is 13.6 percentage points above the measured one; the whole stated range lies above it.
By their numbers in this assay, from the lowest: compound 3; then compounds 1 and 2 (each within the scatter of the next).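

In this assay, for the compounds shown here, 2,5-dimethylphenyl in place of 3,5-dimethylphenyl on an amine nitrogen in a ring gives a number 10.6 percentage points lower from compound 1 to compound 3 (beyond the scatter), the first step that can be read. The groups that leave and enter have the same atoms and the same counts, so in this pair the arrangement of the two methyl groups alone separates the two read-outs. The position therefore responds to a change that leaves the composition of the compound untouched, at least for this one pair. Still open, going by these compounds, is how a 2,5-dichlorophenyl or an unsubstituted phenyl on the same ring nitrogen would read in this assay, and whether the step would carry over to a core other than that of compound 1. Nothing at hand gives a measured reason for this step.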